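The compounds below may be only part of what the source reports. "The series", "measured", "known", "first", "only" and "open" are said of these compounds alone.

Measured so far:
compound 1, `COc1ccc(C(=O)/C=C/c2cccc(F)c2)c2c1C=CC(C)(C)O2`: > 10000 nM
compound 2, `COc1ccc(C(=O)/C=C/c2cccc([N+](=O)[O-])c2)c2c1C=CC(C)(C)O2`: 4090 nM
compound 3, `COc1ccc(C(=O)/C=C/c2ccccc2)c2c1C=CC(C)(C)O2`: > 10000 nM

In a functional assay on SW-620 cells (Homo sapiens) for antiproliferative activity, read by MTT assay, with a stated time of 24 h (a lower number here means a stronger inhibitor, a higher number a weaker inhibitor), compound 3 sits at > 10000 nM; this is a limit of the assay, not a number. Compound 1 sits at the same limit. Compound 2 alone gives a number in this assay, 4090 nM. Compound 4, `COc1ccc(C(=O)/C=C/c2cccc(C(F)(F)F)c2)c2c1C=CC(C)(C)O2`, differs from compound 3 by trifluoromethyl in place of hydrogen on an aromatic carbon. Among the measured compounds shown here, the steps that bear on it are an at least 2.4-fold higher number from compound 2 to compound 3 (0.38 log units; beyond the scatter) and a step that the two limits leave unreadable from compound 1 to compound 3; neither involves trifluoromethyl, and the second cannot be read. With two of three values at the limit of > 10000 nM in this assay, at which 2 of the 3 values shown sit, any number for compound 4 is uncertain in this assay, and a limit is as likely as not. Compound 4 is expected at 8000 nM (range 2500 nM to 25000 nM), meaning an expected at least 1.2-fold lower number from compound 3 to compound 4 (0.09 log units; that floor lies within the scatter).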

Compound 4, half-maximal inhibitory concentration: 7870 nM
Estimate against measurement, compound 4: 1.0-fold (0.01 log units) above; measured number inside the range.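

On this aromatic carbon, meta to a large group, trifluoromethyl joins nitro in giving a number in this assay, whereas fluoro and hydrogen stay at the limit: the limit of > 10000 nM in this assay, at which 2 of the 4 values shown sit.

Against those two limits, the series shows an at least 1.2-fold lower number from compound 3 to compound 4 (0.10 log units; that floor lies within the scatter) and an at least 1.2-fold lower number from compound 1 to compound 4 (0.10 log units; that floor lies within the scatter), so no gain over hydrogen or fluoro is established. Against nitro, it shows a 1.9-fold higher number from compound 2 to compound 4 (0.28 log units; within the scatter), so these two groups cannot be ranked here.

From the compounds shown here alone, whether an amine or a carboxylic acid on this carbon would give a number remains open.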